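The source may hold more compounds than are shown below. What is called first, only, known or untested is meant among the compounds shown, and "the series" means these compounds.

Measured compounds: compound 1 `CCc1ccc(Nc2cc(NC(=O)Nc3cc(OC)cc(OC)c3)ncn2)cc1` with 66.2%; compound 2 `COc1ccc(F)cc1Nc1cc(NC(=O)Nc2c(Cl)cccc2Cl)ncn1` with 78%; compound 3 `Cc1cc(F)cc(Nc2cc(NC(=O)Nc3c(Cl)cccc3Cl)ncn2)c1` with 49.1%, all in a functional assay on HCC827 cells (Homo sapiens) for inhibition, read by MTT assay, with a stated time of 48 h, tested at 10 uM; on this read-out higher numbers stand for more inhibition at the one concentration tested (going by the name of the read-out) and lower numbers for less inhibition.

Compound 1 stands second highest of the three numbers: compound 2 lies higher and compound 3 lower, both gaps beyond the scatter. Compound 4 `COc1cc(NC(=O)Nc2cc(Nc3ccc(F)c(Cl)c3)ncn2)cc(OC)c1` has not been measured; it differs from compound 1 in one place, (3-chloro-4-fluorophenyl in place of 4-ethylphenyl on a nitrogen on an aromatic ring). Within the data shown here, only one measured step touches the same place, a number 28.9 percentage points lower from compound 2 to compound 3 (beyond the scatter), and there the group on that nitrogen was exchanged on a core carrying a different urea aryl. Among the measured compounds shown here, no measured step pairs 4-ethylphenyl against 3-chloro-4-fluorophenyl. A change of this kind has so far moved the read-out by a modest amount; the direction for compound 4 is uncertain, so a step of a number 8.2 percentage points lower from compound 1 to compound 4 (within the scatter) is expected, with a wide range. Compound 4 is estimated at 58%, between 32% and 82%.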

Compound 4, a percentage reported as inhibition, at one concentration (the size of the read-out at that concentration, not a potency): 53.1%
Compound 4: middle estimate off by 4.9 percentage points, on the high side; the range from low to high includes it.
By their numbers in this assay, from the lowest: compounds 3 and 4 (each within the scatter of the next); then compound 1; then compound 2.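

In this assay, among these compounds, placing 3-chloro-4-fluorophenyl in place of 4-ethylphenyl on the nitrogen gives a number 13.1 percentage points lower from compound 1 to compound 4 (beyond the scatter) and is the first direct comparison of these two groups at this position. The position therefore moves the read-out on the core of compound 1 as well as on the core of compound 2. Nothing available explains this step.

Going by these compounds, whether the same exchange has a similar effect on the core of compound 2 remains open. Also open, on these data alone, is how a phenyl carrying an amine or a carboxylic acid would read at this position.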